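The source may report more compounds than this note shows. Statements on the series, on what has been measured and on what is new or still open speak of the compounds shown alone.

Measured in a physicochemical assay for solubility; on this read-out higher numbers stand for higher solubility and lower numbers for lower solubility:
- compound 1 `O=C(c1ccccc1)N1CCC(NS(=O)(=O)c2cc(S(=O)(=O)c3ccccc3)ccc2C(F)(F)F)CC1`: 12500 nM
- compound 2 `N#Cc1cccc(S(=O)(=O)N2CCC(NS(=O)(=O)c3cc(S(=O)(=O)c4ccccc4)ccc3C(F)(F)F)CC2)c1`: 6300 nM
- compound 3 `O=C(CC1CCNCC1)N1CCC(NS(=O)(=O)c2cc(S(=O)(=O)c3ccccc3)ccc2C(F)(F)F)CC1`: 100000 nM

Not yet measured: compound 4 `O=C([C@@H]1CCNC1)N1CCC(NS(=O)(=O)c2cc(S(=O)(=O)c3ccccc3)ccc2C(F)(F)F)CC1`.

Compound 3 stands highest of the three measured compounds, with 100000 nM. Its lead is beyond the scatter on both sides, as shown by an 8.0-fold higher number from compound 1 to compound 3 (0.90 log units; beyond the scatter) and a 16-fold higher number from compound 2 to compound 3 (1.20 log units; beyond the scatter). The remaining pair differs only within the scatter, with a 2.0-fold lower number from compound 1 to compound 2 (0.30 log units; within the scatter).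

Compound 4 carries pyrrolidin-3-yl in place of (piperidin-4-yl)methyl on a carbonyl carbon. The closest measured change is an 8.0-fold higher number from compound 1 to compound 3 (0.90 log units; beyond the scatter), a modest step at the same carbonyl carbon, but it replaced phenyl with a non-aromatic ring group. The large step of a 16-fold higher number from compound 2 to compound 3 (1.20 log units; beyond the scatter) exchanged the whole group on the amine nitrogen, so it bears on this change less directly. Going by the values given here, no measured pair exchanges one non-aromatic nitrogen ring group for another, and neither step therefore gives the size of this change directly. Both groups in the new change are of that kind, so no step beyond the scatter is expected in this assay. The estimated step is a 1.3-fold lower number from compound 3 to compound 4 (0.10 log units; within the scatter). For compound 4 the expected value is 80000 nM, with an estimated range of 30000 nM to 150000 nM.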

Compound 4, solubility: 12500 nM
Compound 4: the middle estimate sits 6.4-fold (0.81 log units) above what was measured, and the stated range ends above it.
By their numbers in this assay, from the lowest: compounds 2, 1 and 4 (each within the scatter of the next); then compound 3.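

In this assay, the outcome at this carbonyl carbon depends on which non-aromatic nitrogen ring group is present: pyrrolidin-3-yl in place of (piperidin-4-yl)methyl gives a step beyond the scatter (an 8.0-fold lower number from compound 3 to compound 4 (0.90 log units; beyond the scatter)). The high reading of compound 3 therefore does not extend to every group of this kind, and a non-aromatic ring on the carbonyl carbon does not by itself set a compound apart from the phenyl analogue (no change at the digits printed from compound 1 to compound 4 (within the scatter)) or from the (3-cyanophenyl)sulfonyl analogue (a 2.0-fold higher number from compound 2 to compound 4 (0.30 log units; within the scatter)). No measurement available here bears on the reason for the step.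

The change from compound 3 to compound 4 alters the ring size, removes the methyl link and introduces a defined stereocentre, and this single step cannot separate those differences. The compounds shown leave open how a piperidin-4-yl group attached directly to the carbonyl carbon, a (pyrrolidin-3-yl)methyl group, or the opposite stereoisomer of the pyrrolidin-3-yl group would read, and each would isolate one part of the change.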